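The source may report more compounds than this note shows. Statements on the series, on what has been measured and on what is new or still open speak of the compounds shown alone.

Within the data shown here, in a functional assay (muscle tissue) with Cavia porcellus as the target (on this read-out higher numbers stand for an effect only at larger amounts of compound and lower numbers for an effect already at smaller amounts), compound 3 (`COC(=O)C1=C(C)N=C(C)/C(=C(\O)OC)C1c1ccccc1F`) gives 42.7 nM, the middle of the three numbers so far. Compound 1 (`COC(=O)C1=C(C)N=C(C)/C(=C(\O)OC)C1c1cccc(OC)c1`) gives 191 nM, and compound 2 (`COC(=O)C1=C(C)N=C(C)/C(=C(\O)OC)C1c1ccccc1C(F)(F)F`) gives 1.51 nM. Compound 4 (`CCc1ccccc1C1C(C(=O)OC)=C(C)N=C(C)/C1=C(\O)OC`) carries ethyl in place of fluoro on an aromatic carbon, ortho to a large group: ethyl in place of fluoro on an aromatic carbon. The closest evidence also exchanges a group for fluoro on an aromatic carbon: a 28-fold higher number from compound 2 to compound 3 (1.45 log units; beyond the scatter), a large step. The step of a 4.5-fold lower number from compound 1 to compound 3 (0.65 log units; beyond the scatter) is modest and exchanges the whole substituted phenyl. Among the measured compounds shown here, no ethyl compound has been measured, so, with compound 2 at 1.51 nM as the guide, a modest move towards a lower number is expected. The expected step is a 3.6-fold lower number from compound 3 to compound 4 (0.55 log units; beyond the scatter). Compound 4 is estimated at 12 nM, within a range from 2.5 nM to 60 nM.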

Compound 4, half-maximal effective concentration: 6.46 nM
The estimate for compound 4 lay 1.9-fold (0.27 log units) above the measured number; the range from low to high includes it.
By their numbers in this assay, from the lowest: compound 2; then compound 4; then compound 3; then compound 1.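

In this assay ethyl, a group without fluorine, takes the number well away from that of the fluoro compound (a 6.6-fold lower number from compound 3 to compound 4 (0.82 log units; beyond the scatter)). It leaves only a modest gap to trifluoromethyl (a 4.3-fold higher number from compound 2 to compound 4 (0.63 log units; beyond the scatter)), so at this place on the aromatic ring fluorine itself is not required for a low number, and the exchange of the whole substituted phenyl is large (a 30-fold lower number from compound 1 to compound 4 (1.47 log units; beyond the scatter)). Nothing measured here gives a reason for these steps. From the compounds shown here alone, whether a propyl chain or an amine at this place would land nearer compound 2 or compound 3 stays open.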